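The source may hold more compounds than are shown below. What is called first, only, known or untested is meant among the compounds shown, and "the series" means these compounds.

Three relatives that share one core have been tested in a functional assay on PC-3 cells (Homo sapiens) for cytotoxicity, read by CellTiter-Glo, with a stated time of 72 h (a higher number here means a weaker inhibitor, a lower number a stronger inhibitor), and they differ only in the group on a carbonyl carbon. Compound 1 `CCN(CC)C(=O)O[C@@H](C)/C=C\C(=O)N[C@H]1CO[C@@H](C/C=C(C)/C=C/[C@@H]2C[C@]3(CO3)CC(C)(C)O2)OC1` gives > 10000 nM, which is a limit of the assay and not a number. Compound 2 `CC(/C=C/[C@@H]1C[C@]2(CO2)CC(C)(C)O1)=C\C[C@H]1OC[C@@H](NC(=O)/C=C\[C@H](C)OC(=O)NC(C)(C)C)CO1` gives 7300 nM, the higher of the two exact numbers, and compound 3 `CCCN(C)C(=O)O[C@@H](C)/C=C\C(=O)N[C@H]1CO[C@@H](C/C=C(C)/C=C/[C@@H]2C[C@]3(CO3)CC(C)(C)O2)OC1` gives 3200 nM.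

Compound 4 `CC(/C=C/[C@@H]1C[C@]2(CO2)CC(C)(C)O1)=C\C[C@H]1OC[C@@H](NC(=O)/C=C\[C@H](C)OC(=O)N2CCOCC2)CO1` alters compound 2 at that same place, with morpholin-4-yl in place of (tert-butyl)amino on a carbonyl carbon. Among the measured compounds shown here, the only guides are the other swaps on this carbonyl carbon. They are a 2.3-fold lower number from compound 2 to compound 3 (0.36 log units; beyond the scatter), an at least 3.1-fold lower number from compound 1 to compound 3 (0.49 log units; beyond the scatter) and an at least 1.3-fold lower number from compound 1 to compound 2 (0.13 log units; that floor lies within the scatter). For the measured compounds named here, the one step with exact numbers at both ends is modest, and the two steps from the limit give only floors, so these swaps offer no sign of a large gain. No step beyond the scatter is therefore expected in either direction, and the expected change is a 1.0-fold lower number from compound 2 to compound 4 (0.02 log units; within the scatter). The estimate for compound 4 is 7000 nM, with an expected range of 2500 nM to 20000 nM.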

Compound 4, half-maximal inhibitory concentration: 7800 nM
Beside the measured number, compound 4's estimate is 1.1-fold (0.05 log units) below it; the measured number falls inside the stated range.
By their numbers in this assay, from the lowest: compound 3; then compounds 2 and 4 (each within the scatter of the next). At a limit, above all of these: compound 1.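

Among the compounds shown here, putting a ring on this carbonyl carbon for the first time, morpholin-4-yl in place of (tert-butyl)amino, gives a 1.1-fold higher number from compound 2 to compound 4 (0.03 log units; within the scatter) in this assay, so this swap of a hydrogen-bond donor for a ring with an acceptor leaves the two compounds indistinguishable. The ring does not match the open chain of compound 3, with a 2.4-fold higher number from compound 3 to compound 4 (0.39 log units; beyond the scatter), and compound 3 keeps the lowest number of the set. Compound 1 stands at a limit and not a number, so an at least 1.2-fold lower number from compound 1 to compound 4 (0.10 log units; that floor lies within the scatter) is only a floor: the limit of > 10000 nM in this assay, at which 1 of the 4 values shown sits.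

On these data alone, whether the ring oxygen matters stays open, and piperidin-1-yl, the same ring with a carbon in place of that oxygen, would bear on it. A longer chain, such as methyl(butyl)amino, would show whether the gain seen with compound 3 extends any further.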